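Replacing a Methoxy by Dimethylcarbamoyl: an Expected Loss

This account rests on a few compounds, and the source may have more. Where it says the series, first, only, none or still open, it means among the compounds named here.

Compound 1 `C=Cc1nc(CC)n2c1C(CCc1ccc(C(F)(F)F)cc1)N([C@@H](C(=O)NC)c1ccccc1)CC2` gives 150 nM in a functional assay on CHO cells for antagonist activity at Orexin/Hypocretin receptor type 1 (Homo sapiens), read by FLIPR and calcium flux; on this read-out higher numbers stand for weaker inhibition and lower numbers for stronger inhibition. Compound 2 `CCOc1nc(CC)n2c1C(CCc1ccc(C(F)(F)F)cc1)N([C@@H](C(=O)NC)c1ccccc1)CC2` gives 3980 nM in this assay. Compound 3 `CCc1nc(OC)c2n1CCN([C@@H](C(=O)NC)c1ccccc1)C2CCc1ccc(C(F)(F)F)cc1` gives 134 nM in this assay.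

Compound 3 has the lowest number of the three, yet its separation from compound 1 is only a 1.1-fold lower number from compound 1 to compound 3 (0.05 log units; within the scatter), so the two cannot be ranked; its separation from compound 2 is a 30-fold lower number from compound 2 to compound 3 (1.47 log units; beyond the scatter). Compound 4 `CCc1nc(C(=O)N(C)C)c2n1CCN([C@@H](C(=O)NC)c1ccccc1)C2CCc1ccc(C(F)(F)F)cc1` differs from compound 3 by dimethylcarbamoyl in place of methoxy on an aromatic carbon. The step that bears on this is a 27-fold higher number from compound 1 to compound 2 (1.42 log units; beyond the scatter), where a larger group at the same carbon cost heavily, mirrored by a 30-fold lower number from compound 2 to compound 3 (1.47 log units; beyond the scatter). Since the entering group is larger still, compound 4 is expected to show weaker inhibition, by an 11-fold higher number from compound 3 to compound 4 (1.05 log units; beyond the scatter). The estimate for compound 4 is 1500 nM, within 300 nM to 8000 nM.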

Compound 4, half-maximal inhibitory concentration: 344 nM
Compound 4: middle estimate off by 4.4-fold (0.64 log units), on the high side, and the stated range covers the measured number.
By their numbers in this assay, from the lowest: compounds 3 and 1 (each within the scatter of the next); then compound 4; then compound 2.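

At this aromatic carbon, group size alone does not set the outcome in this assay. Dimethylcarbamoyl, with 5 heavy atoms, gives only a 2.6-fold higher number from compound 3 to compound 4 (0.41 log units; beyond the scatter) and a 2.3-fold higher number from compound 1 to compound 4 (0.36 log units; beyond the scatter) while it gives a 12-fold lower number from compound 2 to compound 4 (1.06 log units; beyond the scatter), so the smaller ethoxy goes against any ordering by size among these compounds. No measurement available here explains this gap.

On these data alone, whether a carboxylic acid, a primary amide or an aminomethyl group at this carbon would fall nearer to dimethylcarbamoyl or to ethoxy remains open.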